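Swapping the amine substituents on compound 3

The source may hold more compounds than are shown below. What is called first, only, known or untested is meant among the compounds shown, and "the series" means these compounds.

Of the compounds shown here, three built on a shared core have been measured in an assay on HEK293 cells for inhibition of Steryl-sulfatase (Homo sapiens), tested at 1 uM; a higher number here means a stronger effect of the compound at the concentration tested, a lower number a weaker effect. Compound 1 `CN(C)CCCN(Cc1ccccc1)c1ccc(C(=O)N2CCc3ccc(OS(N)(=O)=O)cc3C2)cc1` gives 61.6%, compound 2 `CCN(Cc1ccc(Br)cc1)c1ccc(C(=O)N2CCc3ccc(OS(N)(=O)=O)cc3C2)cc1` gives 95.9%, and compound 3 `CCN(Cc1cccc(Br)c1)c1cccc(C(=O)N2CCc3ccc(OS(N)(=O)=O)cc3C2)c1` gives 24.9%, the lowest of the three, standing below compound 1 and further below compound 2 by margins beyond the scatter. Compound 4 `CCCN(Cc1ccccc1)c1cccc(C(=O)N2CCc3ccc(OS(N)(=O)=O)cc3C2)c1` has not yet been measured. It differs from compound 3 in one place: benzyl(propyl)amino in place of (3-bromobenzyl)(ethyl)amino on an aromatic carbon. Among the measured compounds shown here, no measured pair isolates this change, so the expected step of a number 5.1 percentage points higher from compound 3 to compound 4 (within the scatter) is small, in either direction, and not clearly beyond the scatter. On that basis compound 4 is estimated at 30% in this assay, with a likely range from 10% to 60%.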

Compound 4, a percentage reported as inhibition, at one concentration (the size of the read-out at that concentration, not a potency): 67.4%
For compound 4 the middle estimate is 37.4 percentage points below the measured one; the whole stated range lies below it.
By their numbers in this assay, from the lowest: compound 3; then compounds 1 and 4 (each within the scatter of the next); then compound 2.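

At this position, on an aromatic carbon meta to a large group, the amine substituents matter a great deal: in this assay, benzyl(propyl)amino in place of (3-bromobenzyl)(ethyl)amino gives a number 42.5 percentage points higher from compound 3 to compound 4 (beyond the scatter). The two groups have the same heavy-atom count, one six-membered aromatic ring each and no net charge, so these counts do not separate them. Nothing available explains the step. As far as these compounds go, the swap removes the bromine and turns ethyl into propyl at once, so which change carries the step stays open. A benzyl(ethyl)amino or (3-bromobenzyl)(propyl)amino group would separate the two.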